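The source may hold more compounds than are shown below. What is called first, only, known or untested is meant among the compounds shown, and "the series" means these compounds.

Working notes on the series: in a functional assay on DU-145 cells (Homo sapiens) for antiproliferative activity, read by MTT assay, with a stated time of 48 h (on this read-out lower numbers stand for stronger inhibition and higher numbers for weaker inhibition), compound 1 (`COc1cc(-c2nnc(-c3cn4ccccc4n3)o2)cc(OC)c1OC`) gives 4500 nM, and compound 2 (`COc1ccc(-c2nnc(-c3cn4cccc(C)c4n3)o2)cc1OC`) gives 11800 nM, the higher of the two numbers by a gap beyond the scatter. Compound 3 (`COc1cc(-c2nnc(-c3cn4cccc(C)c4n3)o2)cc(OC)c1OC`) differs from compound 2 by methoxy in place of hydrogen on an aromatic carbon. Among the measured compounds shown here, no measured pair isolates this change. A moderate drop in this assay is expected, since compound 3 shares its methoxy-bearing ring with compound 1 at 4500 nM. The expected change is a 2.1-fold lower number from compound 2 to compound 3 (0.33 log units; beyond the scatter). The estimated value for compound 3 is 5500 nM, with an expected range of 2000 nM to 13000 nM.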

Compound 3, half-maximal inhibitory concentration: 11200 nM
Compound 3: middle estimate off by 2.0-fold (0.31 log units), on the low side, within the range that was stated.
By their numbers in this assay, from the lowest: compound 1; then compounds 3 and 2 (each within the scatter of the next).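

In this assay, methoxy in place of hydrogen on the aromatic carbon ortho to a methoxy group gives a 1.1-fold lower number from compound 2 to compound 3 (0.02 log units; within the scatter), so this added methoxy makes no measurable difference when the methyl is present. Methyl in place of hydrogen on an aromatic carbon gives a 2.5-fold higher number from compound 1 to compound 3 (0.40 log units; beyond the scatter), a modest loss with the methoxy-bearing ring held constant. Nothing available explains either step.

From the compounds shown here alone, whether the added methoxy would also make no difference without the methyl remains open. So does the outcome with an amine or a carboxylic acid on the same aromatic carbon.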